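The source may hold more compounds than are shown below. What is called first, only, known or untested is meant among the compounds shown, and "the series" means these compounds.

Measured compounds:
- compound 1, `Cn1nnc2cc(C(N)=O)ccc2c1=O`: 380000 nM
- compound 2, `Cn1nnc2c(C(N)=O)cccc2c1=O`: > 500000 nM

In a functional assay on TLX-5 cells (Mus musculus) for cytotoxicity (on this read-out higher numbers stand for weaker inhibition and lower numbers for stronger inhibition), compound 1 gives 380000 nM. For compound 2 the reported value > 500000 nM is a limit of this assay and not a number; it sits at the limit of > 500000 nM in this assay, at which 1 of the 2 values shown sits. Of the two values shown, compound 2 thus stands at the limit and compound 1 a little inside it. Going by the values given here, no step between measured compounds that differ in one place is available.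

Compound 3, `CCn1nnc2c(C(N)=O)cccc2c1=O`, is not yet measured. It differs from compound 2 by methyl in place of hydrogen on a saturated chain carbon bound to an aromatic nitrogen, which read one bond further out is methyl to ethyl. For this step in this assay no change beyond the usual scatter is expected, and the result may again come back as a limit. Compound 3 is expected near 600000 nM, within 200000 nM to 2000000 nM. The step that the limit leaves unreadable from compound 2 to compound 3 is accordingly expected to be small.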

Compound 3, half-maximal inhibitory concentration: 325000 nM
For compound 3 the middle estimate is 1.8-fold (0.27 log units) above the measured one; low and high end bracket the measured number.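

With methyl in place of hydrogen on a saturated chain carbon bound to an aromatic nitrogen, compound 3 gives a number in this assay, 325000 nM, so this change can now be read against a measured value. For compound 2 the reported value is a limit of the assay and not a number: the limit of > 500000 nM in this assay, at which 1 of the 3 values shown sits. The change therefore reads only as an at least 1.5-fold lower number from compound 2 to compound 3 (0.18 log units; that floor lies within the scatter), a floor and not a size, and that floor does not separate the step from the scatter.

On these data alone, the true size of this step stays open, as does whether the same change on the core of compound 1 would behave alike. Also open, as far as these compounds go, is what a longer chain such as propyl, or an amine or a carboxylic acid at the end of that chain, would do in this assay.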